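A Second Amine Ring Swap on the Same Side Chain

The source may report more compounds than this note shows. Statements on the series, on what has been measured and on what is new or still open speak of the compounds shown alone.

Compound 1 `COc1c(OCCCCN2CCCCC2)cc(O)c2c(=O)cc(-c3ccccc3)oc12` and compound 2 `COc1c(OCCCCN2CCCC2)cc(O)c2c(=O)cc(-c3ccccc3)oc12` share one core and differ only in the amine ring that closes a four-carbon chain. In a functional assay on A549 cells (Homo sapiens) for cytotoxicity, read by MTT assay, with a stated time of 48 h (a higher number here means a weaker inhibitor, a lower number a stronger inhibitor), compound 1 gives 1150 nM, and compound 2 gives 1530 nM. The step of a 1.3-fold higher number from compound 1 to compound 2 (0.12 log units; within the scatter) leaves the two numbers within the usual scatter of each other, so compound 2 stands level with compound 1 rather than apart from it.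

Compound 3 `COc1c(OCCCCN2CCN(C)CC2)cc(O)c2c(=O)cc(-c3ccccc3)oc12` carries the same chain but with 4-methylpiperazin-1-yl in place of pyrrolidin-1-yl on a saturated chain carbon, four bonds along the chain from an oxygen on an aromatic ring. Among the compounds with values here, the one measured step that bears on this change is the ring swap from compound 1 to compound 2, which produced no step beyond the scatter. A further exchange of the terminal amine ring is therefore expected to move the number little, and the expected step is a 1.1-fold higher number from compound 2 to compound 3 (0.05 log units; within the scatter). Compound 3 is thus estimated at 1700 nM, with a range from 700 nM to 4000 nM.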

Compound 3, half-maximal inhibitory concentration: 1500 nM
Estimate against measurement, compound 3: 1.1-fold (0.05 log units) above; the measured number falls inside the stated range.
By their numbers in this assay, from the lowest: compounds 1, 3 and 2 (each within the scatter of the next).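

Exchanging pyrrolidin-1-yl for 4-methylpiperazin-1-yl on the end of the chain gives a 1.0-fold lower number from compound 2 to compound 3 (0.01 log units; within the scatter) in this assay, and exchanging piperidin-1-yl for the same group gives a 1.3-fold higher number from compound 1 to compound 3 (0.12 log units; within the scatter). The earlier pair compared only rings with a single nitrogen, whereas this result shows that a ring with two nitrogens and a methyl group also stands level with both, so all three amine rings at this position read alike in this assay. Nothing measured here speaks to why these rings read alike.

All three compounds shown end the four-carbon chain in a saturated amine ring, so it remains open whether a morpholine ring, an open-chain dimethylamino group or a carboxylic acid in that place would stand apart from them. Whether a shorter or longer chain would do so is open as well.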